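An Ester Gives Way to an Amide

The source may report more compounds than this note shows. Statements on the series, on what has been measured and on what is new or still open speak of the compounds shown alone.

Compound 1 `CCCCOC(=O)c1ccc(COC(COCc2ccc(OC)cc2)Cn2ccnc2)cc1` is tested in a functional assay for inhibition of Thromboxane-A synthase (Homo sapiens) (on this read-out lower numbers stand for stronger inhibition and higher numbers for weaker inhibition), where compound 1 gives 200 nM. A related ester, compound 2 `CCOC(=O)c1cccc(COC(COCc2ccc(OC)cc2)Cn2ccnc2)c1`, gives 7200 nM in this assay, so compound 1 stands at the lower of the two numbers, and the gap between them lies beyond the scatter. Compound 3 `CCNC(=O)c1ccc(COC(COCc2ccc(OC)cc2)Cn2ccnc2)cc1` differs from compound 1 by a single change: ethylamino in place of butoxy on a carbonyl carbon. Within the data shown here, no measured pair shows this change, so its effect is not known. The expected step of a 3.5-fold higher number from compound 1 to compound 3 (0.54 log units; beyond the scatter) points toward a higher number, beyond the scatter. Compound 3 is therefore estimated at 700 nM, within a range from 150 nM to 3500 nM.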

Compound 3, half-maximal inhibitory concentration: 12400 nM
Compound 3: the middle estimate sits 18-fold (1.25 log units) below what was measured; measured number outside the range, above it.
By their numbers in this assay, from the lowest: compound 1; then compounds 2 and 3 (each within the scatter of the next).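

Ethylamino in place of butoxy on a carbonyl carbon brings a 62-fold higher number from compound 1 to compound 3 (1.79 log units; beyond the scatter). Among these compounds, this is the first step here that isolates a single change, and it shows that what sits on this carbonyl carbon matters strongly for inhibition; compound 1 and compound 2 differ in more than one place, so they could not show this. Nothing measured here explains the size of this step.

As far as these compounds go, the swap alters both the linking atom and the chain, so it remains open which of the two carries the loss. Butylamino on the same carbonyl carbon would separate them, and how a carboxylic acid there would read is unknown.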